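The source may hold more compounds than are shown below. What is called first, only, known or untested is meant among the compounds shown, and "the series" means these compounds.

Among the measured compounds shown here, compound 2 `O=C(/C=C/c1ccc(Cl)c(Cl)c1)c1ccc(NC(=S)Nc2ccc(Cl)cc2)cc1` gives 6.15 umol/kg in a functional assay on the whole organism (Abdomen, strain Swiss) with Mus musculus as the target, with a stated time of 30 min (a higher number here means that more compound is needed for the effect, a lower number that less compound is needed), the lower of the two numbers measured so far; its nearest neighbour is compound 1 `COc1ccc(/C=C/C(=O)c2ccc(NC(=S)Nc3ccc(Cl)cc3)cc2)cc1`, which gives 10.4 umol/kg in this assay. Compound 3 `O=C(/C=C/c1ccccc1)c1ccc(NC(=S)Nc2ccc(Cl)cc2)cc1` differs from compound 2 in one place: phenyl in place of 3,4-dichlorophenyl on a double-bonded chain carbon bound to a double-bonded chain carbon. For the measured compounds named here, the only comparable step is a 1.7-fold lower number from compound 1 to compound 2 (0.23 log units; within the scatter), which swapped one aryl group for another at the same place and stayed within the scatter. Compound 3 is therefore expected to show a step of a 1.4-fold higher number from compound 2 to compound 3 (0.14 log units; within the scatter), again within the scatter. In this assay compound 3 is estimated at 8.5 umol/kg, ranging from 4 umol/kg to 18 umol/kg.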

Compound 3, dose for 50% inhibition: 3.03 umol/kg
Compound 3: middle estimate off by 2.8-fold (0.45 log units), on the high side; the measured number lies below the stated range.
By their numbers in this assay, from the lowest: compound 3; then compounds 2 and 1 (each within the scatter of the next).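

In this assay, among the compounds shown here, the plain phenyl ring gives the first change at this place that exceeds the scatter: phenyl in place of 3,4-dichlorophenyl brings a 2.0-fold lower number from compound 2 to compound 3 (0.31 log units; beyond the scatter) and hydrogen in place of methoxy on an aromatic carbon brings a 3.4-fold lower number from compound 1 to compound 3 (0.54 log units; beyond the scatter). Among these three compounds, both substituted rings need more compound than the unsubstituted one, making compound 3 the most potent. Nothing measured here gives a reason for this. Going by these compounds, whether a single chlorine, an amine or a carboxylic acid on this ring would also raise the number stays open, as does the effect of a pyridine in place of the phenyl.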